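The source may report more compounds than this note shows. Statements on the series, on what has been measured and on what is new or still open speak of the compounds shown alone.

Measured so far:
- compound 1 `Cc1oc2c([C@H]3CCN(C)C[C@H]3O)c(O)cc(O)c2c(=O)c1C(O)c1ccc(F)c(Br)c1`: 72%
- compound 2 `Cc1oc2c([C@H]3CCN(C)C[C@H]3O)c(O)cc(O)c2c(=O)c1C(O)c1csc([N+](=O)[O-])c1`: 0%
- compound 3 `CCOc1ccc(Br)c(C(O)c2c(C)oc3c([C@H]4CCN(C)C[C@H]4O)c(O)cc(O)c3c2=O)c1`: 0%

These values come from a functional assay on PC-3 cells (Homo sapiens) for inhibition, read by MTT assay, with a stated time of 48 h, tested at 10 uM; on this read-out lower numbers stand for less inhibition of growth and higher numbers for more inhibition of growth at the one concentration tested. Compound 3, at 0%, stands level with compound 2, and together they hold the lowest of the three numbers.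

Compound 4 `Cc1oc2c([C@H]3CCN(C)C[C@H]3O)c(O)cc(O)c2c(=O)c1C(O)c1cccc(Cl)c1Cl` has not yet been measured. It carries 2,3-dichlorophenyl in place of 2-bromo-5-ethoxyphenyl on a saturated chain carbon bound to an aromatic carbon and an oxygen on a saturated carbon.

The measured steps at this same place are a number 72 percentage points lower from compound 1 to compound 2 (beyond the scatter), a number 72 percentage points lower from compound 1 to compound 3 (beyond the scatter) and no change at the digits printed from compound 2 to compound 3 (within the scatter). Changes here can therefore be very large or show nothing. Compound 4 resembles compound 1 in having a halogen-bearing phenyl ring without ethoxy. That hint is weak, since compound 3 also carries bromine and gives only 0%. A moderate rise in this assay is expected, with much uncertainty, estimated as a number 30 percentage points higher from compound 3 to compound 4 (beyond the scatter). For compound 4 the estimated value is 30%, with an expected range from 0% to 75%.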

Compound 4, percent growth inhibition at one concentration: 20%
Beside the measured number, compound 4's estimate is 10 percentage points above it; low and high end bracket the measured number.
By their numbers in this assay, from the lowest: compounds 2 and 3 (each within the scatter of the next); then compound 4; then compound 1.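

In this assay, this position is not limited to the two extremes seen so far. The 2,3-dichlorophenyl group gives a result in between: a number 20 percentage points higher from compound 3 to compound 4 (beyond the scatter) and a number 20 percentage points higher from compound 2 to compound 4 (beyond the scatter), while a number 52 percentage points lower from compound 1 to compound 4 (beyond the scatter). Carrying halogen on a phenyl ring does not settle the outcome, since compound 1, compound 3 and compound 4 all do so, yet their numbers differ beyond the scatter. Nothing available explains why these rings give such different numbers.

The compounds shown leave open where a phenyl ring with a single chlorine, or one bearing an amine or a carboxylic acid, would fall relative to compound 1 and compound 3. They also leave open whether an unsubstituted phenyl ring would give any growth inhibition at all.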